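Amide variation on the shared acrylamide core

A few compounds are considered here, and "the series" means these few. Any claim that something is new, unique, unknown or untested is made for them only; others in the source may bear on it.

Compound 2 `CNC(=O)/C=C/c1ccncc1-c1ccc2c(cnn2C)c1` holds the lowest of the two numbers in hand: in an assay on a protein complex for inhibition of CDK8/Cyclin C (Homo sapiens), with a stated time of 1 h (a higher number here means a weaker inhibitor, a lower number a stronger inhibitor), compound 2 gives 86.7 nM, while compound 1 `CCOC(=O)/C=C/c1ccncc1-c1ccc2c(ccn2C)c1` gives 144 nM, a gap that lies within the scatter. Compound 3 `Cn1ncc2cc(-c3cnccc3/C=C/C(=O)N3CCOCC3)ccc21` differs from compound 2 in one place: morpholin-4-yl in place of methylamino on a carbonyl carbon. Among the measured compounds shown here, no measured pair shows this change, so the expectation is a small step, if anything towards a weaker inhibitor, possibly no further than the scatter. In this assay compound 3 is estimated at 150 nM, with a range of 50 nM to 450 nM. The expected step is a 1.7-fold higher number from compound 2 to compound 3 (0.24 log units; within the scatter).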

Compound 3, half-maximal inhibitory concentration: 356 nM
Beside the measured number, compound 3's estimate is 2.4-fold (0.38 log units) below it; the range from low to high includes it.
By their numbers in this assay, from the lowest: compounds 2 and 1 (each within the scatter of the next); then compound 3.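

Morpholin-4-yl in place of methylamino on a carbonyl carbon gives a 4.1-fold higher number from compound 2 to compound 3 (0.61 log units; beyond the scatter) in this assay, the only single-place step in hand. This position therefore responds to the change, in the direction of a weaker inhibitor. The change removes a hydrogen-bond donor and adds a six-membered ring together, and nothing measured here explains the step.

Open, as far as these compounds go, is whether dimethylamino, with no amide hydrogen and no ring, stays near compound 2 or moves towards compound 3. Piperidin-1-yl, which keeps the ring without its oxygen, is equally open.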